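A few compounds are considered here, and "the series" means these few. Any claim that something is new, unique, unknown or untested is made for them only; others in the source may bear on it.

Compound 1 `c1ccc(Oc2ccc3c(NCCCNCc4ccco4)ccnc3c2)cc1` gives, in a physicochemical assay for acid dissociation, a value of 9.28. Compound 2 `COc1ccc(Oc2ccc3c(NCCCNCc4cccc(OC)c4O)ccnc3c2)cc1` gives in this assay 9.28. Compound 3 `COc1cccc(CNCCCNc2ccnc3cc(CCC(C)C)ccc23)c1O` gives in this assay 9.47, and its number stands apart from those of compound 1 and compound 2 only by amounts within the usual scatter, so the three are not distinguished. Within the data shown here, the one measured step that touches this position is a number 0.19 log units higher from compound 2 to compound 3 (within the scatter). Compound 4 `COc1cccc(CNCCCNc2ccnc3cc(Oc4ccccc4)ccc23)c1O` is not yet measured; it differs from compound 3 by phenoxy in place of isopentyl on an aromatic carbon. This is the reverse kind of change to the step between compound 2 and compound 3, and compound 1 already carries phenoxy at the same place with its value of 9.28. No step beyond the scatter is therefore expected in this assay. The change is expected to amount to a number 0.17 log units lower from compound 3 to compound 4 (within the scatter), within the scatter. Compound 4 is thus expected to give about 9.3, most likely between 9 and 9.6.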

Compound 4, acid dissociation constant: 9.28
Compound 4: middle estimate off by 0.02 log units, on the high side; low and high end bracket the measured number.
By their numbers in this assay, from the lowest: compounds 1, 2, 4 and 3 (each within the scatter of the next).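

In this assay, phenoxy in place of isopentyl on this aromatic carbon now has a direct reading, a number 0.19 log units lower from compound 3 to compound 4 (within the scatter), so the change is seen on a matched pair and not only through the reverse kind of step. Two further single changes can also be read against compound 4: hydrogen in place of methoxy on an aromatic carbon gives no change at the digits printed from compound 2 to compound 4 (within the scatter), and 2-hydroxy-3-methoxyphenyl in place of furan-2-yl on a saturated chain carbon gives no change at the digits printed from compound 1 to compound 4 (within the scatter). None of the three changes separates its pair of compounds in this read-out.

Whether an amine, a carboxylic acid or a longer chain on this aromatic carbon would give a step beyond the scatter remains open, as the compounds shown carry only phenoxy, 4-methoxyphenoxy and isopentyl there. Nothing at hand offers an explanation for these readings.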